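The compounds below may be only part of what the source reports. "The series", "measured", "known", "first", "only" and "open" are said of these compounds alone.

Three measured compounds share one core, seen in compound 1 `COc1ccc(CN(C(=O)Nc2ccc(C#N)cc2)n2cnnc2)cc1OC`, compound 2 `COc1ccc(CN(C(=O)Nc2ccc(Cl)c(C(F)(F)F)c2)n2cnnc2)cc1OC` and compound 3 `CCc1ccc(NC(=O)N(Cc2ccc(OC)c(OC)c2)n2cnnc2)cc1`, and differ only in the groups on the aryl urea ring. In a functional assay on A549 cells (Homo sapiens) for cytotoxicity, read by MTT assay, with a stated time of 48 h (a lower number here means a stronger inhibitor, a higher number a weaker inhibitor), compound 1 gives only a limit, > 50000 nM, and so sits at the limit of > 50000 nM in this assay, at which 1 of the 3 values shown sits. In this assay compound 2 gives 29300 nM. In this assay compound 3 gives 28400 nM; compound 3 and compound 2 lie within the scatter of each other, so neither is set apart. The single step between measured compounds is an at least 1.7-fold lower number from compound 1 to compound 3 (0.24 log units; that floor lies within the scatter), whose floor is itself within the scatter, so no change beyond the scatter has yet been shown on this ring.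

Compound 4 `COc1ccc(CN(C(=O)Nc2ccc(Cl)cc2)n2cnnc2)cc1OC` is compound 3 with chloro in place of ethyl on an aromatic carbon. Within the data shown here, no measured pair carries this exchange; compound 2, which also bears chloro on that ring, gives a number within the scatter of compound 3. The step of a 1.1-fold higher number from compound 3 to compound 4 (0.02 log units; within the scatter) is therefore expected to stay within the scatter, in no fixed direction. Compound 4 is estimated at 30000 nM in this assay, with a range of 12000 nM to 75000 nM.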

Compound 4, half-maximal inhibitory concentration: 44200 nM
Compound 4: middle estimate off by 1.5-fold (0.17 log units), on the low side; the measured number falls inside the stated range.
By their numbers in this assay, from the lowest: compounds 3, 2 and 4 (each within the scatter of the next). At a limit, above all of these: compound 1.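

The exchange now has a direct pair, which the earlier compounds lacked: a 1.6-fold higher number from compound 3 to compound 4 (0.19 log units; within the scatter), so chloro and ethyl are not told apart at this place, para to a large group, and removing trifluoromethyl from the chlorinated ring, a 1.5-fold higher number from compound 2 to compound 4 (0.18 log units; within the scatter), is not shown to matter either. Cyano in place of chloro remains unresolved, with an at least 1.1-fold lower number from compound 1 to compound 4 (0.05 log units; that floor lies within the scatter). Compound 1 stands only as a limit: the limit of > 50000 nM in this assay, at which 1 of the 4 values shown sits.

No step shown passes the scatter, so it remains open whether any group on this ring changes the number in this assay. An amine, a carboxylic acid or a longer chain in place of chloro would test this more widely than the groups shown here.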